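Nitro to methyl on a shared core: what to expect

The source may hold more compounds than are shown below. What is called first, only, known or untested is meant among the compounds shown, and "the series" means these compounds.

Of the compounds shown here, three built on one shared core have been tested in a functional assay on C6 cells (Rattus norvegicus) for cytotoxicity, read by MTT assay, with a stated time of 24 h, tested at 25 ug/mL; a higher number here means a weaker effect of the compound at the concentration tested, a lower number a stronger effect. Compound 1 `Cc1nnc(SCC(=O)N/N=c2/scc(-c3ccc(F)cc3)n2-c2ccccc2)s1` gives 50.1%. Compound 3 `Cc1nnc(SCC(=O)N/N=c2/scc(-c3ccc(Cl)cc3)n2-c2ccccc2)s1` gives 53.3%. These two differ in a single place, and the step of a number 3.2 percentage points higher from compound 1 to compound 3 (within the scatter) shows that swapping one halogen for another barely moved the read-out. Compound 2 `Cn1nnnc1SCC(=O)N/N=c1/scc(-c2ccc([N+](=O)[O-])cc2)n1-c1ccccc1` gives 69.3%, the highest of the three numbers, meaning the weakest effect at the tested concentration; its distance from compound 3 and from compound 1 lies beyond the scatter in both cases. Compound 2 differs from the other two in more than one place, so no single measured step explains its position.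

Compound 4 `Cc1ccc(-c2cs/c(=N/NC(=O)CSc3nnnn3C)n2-c2ccccc2)cc1` is compound 2 with one change: methyl in place of nitro on an aromatic carbon. Among the measured compounds shown here, no measured step involves a nitro or a methyl group, and the only step that touches the same ring position, the one from compound 1 to compound 3, was within the scatter. On that basis a small change is expected for compound 4, with a step of a number 7.3 percentage points lower from compound 2 to compound 4 (within the scatter) that is not expected to exceed the scatter by much. Compound 4 is therefore estimated at 62%, within a range from 46% to 78%.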

Compound 4, a percentage reported as activity, at one concentration (the size of the read-out at that concentration, not a potency): 60.7%
Compound 4: middle estimate off by 1.3 percentage points, on the high side, within the range that was stated.
By their numbers in this assay, from the lowest: compounds 1, 3, 4 and 2 (each within the scatter of the next, the first and the last beyond it).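

In this assay, the step of a number 8.6 percentage points lower from compound 2 to compound 4 (within the scatter) stays within the scatter, even though the 4-nitrophenyl to 4-methylphenyl change is a larger swap than the earlier one. The earlier step exchanged one halogen for another at this place, so it could only show that two halogens read alike on the core of compound 1. This step shows that the read-out also fails to separate two quite different groups on the core of compound 2: nitro, with its three heavy atoms, nitrogen, oxygen and two hydrogen-bond acceptors, and methyl, a single carbon with no acceptor, both on an aromatic carbon para to a large group, and nothing at hand says why the two read alike.

What stays open is whether this place is as undemanding for groups of another kind, such as an amine, a carboxylic acid or a longer chain like butyl, since only halogens, nitro and methyl are shown here. Also open is whether the distance of compound 2 from compound 1 and compound 3 comes from the other end of the molecule, as no pair shown differs there alone.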